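A few compounds are considered here, and "the series" means these few. Any claim that something is new, unique, unknown or untested is made for them only; others in the source may bear on it.

Working notes on the series. In an ADME assay on BEAS-2B cells (Homo sapiens) for cytotoxicity, read by MTT assay, with a stated time of 72 h (a higher number here means a weaker inhibitor of growth, a lower number a stronger inhibitor of growth), compound 2 `COc1ccc(CNc2nc(SC)nc3ccccc23)cc1` gives 96200 nM. Compound 1 `COc1ccc(CNc2nc([Se]C)nc3ccccc23)cc1` in this assay returns > 100000 nM, which is a limit of the assay and not a number. Compound 1 differs from compound 2 by a group of 2 heavy atoms (1 carbon, 1 selenium; no ring) in place of a group of 2 heavy atoms (1 carbon, 1 sulfur; no ring), on an aromatic carbon; the step of an at least 1.0-fold higher number from compound 2 to compound 1 (0.01 log units; that floor lies within the scatter) rests on (the limit of > 100000 nM in this assay, at which 1 of the 3 values shown sits). Compound 3 `CSc1ccc(CNc2nc(SC)nc3ccccc23)cc1` gives 59100 nM in this assay; its core differs from the core of compound 2 by methylsulfanyl in place of methoxy on an aromatic carbon, and a 1.6-fold lower number from compound 2 to compound 3 (0.21 log units; within the scatter). Compound 4 `CSc1ccc(CNc2nc([Se]C)nc3ccccc23)cc1` awaits measurement in this assay. Its difference from compound 3 is a group of 2 heavy atoms (1 carbon, 1 selenium; no ring) in place of a group of 2 heavy atoms (1 carbon, 1 sulfur; no ring), on an aromatic carbon, the same change as that from compound 2 to compound 1, at a place described in the same words. For compound 4 the expected step is a 1.4-fold higher number from compound 3 to compound 4 (0.13 log units; within the scatter), set beside the earlier at least 1.0-fold higher number from compound 2 to compound 1 (0.01 log units; that floor lies within the scatter), which reached a limit. Compound 4 is therefore estimated at 80000 nM.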

Compound 4, concentration for total growth inhibition: 78500 nM
Compound 4: middle estimate off by 1.0-fold (0.01 log units), on the high side; measured number inside the range.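

In this assay, the selenium-carrying group in place of methylsulfanyl gives a 1.3-fold higher number from compound 3 to compound 4 (0.12 log units; within the scatter), and set beside the earlier step this reads: the same change on two cores in this assay, an at least 1.0-fold higher number (0.01 log units; that floor lies within the scatter) from compound 2 to compound 1 and a 1.3-fold higher number (0.12 log units; within the scatter) from compound 3 to compound 4; the limit leaves it open whether they differ

Methylsulfanyl in place of methoxy, read on the selenium-carrying core, gives an at least 1.2-fold lower number from compound 1 to compound 4 (0.10 log units; that floor lies within the scatter), and set beside the earlier step this reads: the same change on two cores in this assay, a 1.6-fold lower number (0.21 log units; within the scatter) from compound 2 to compound 3 and an at least 1.2-fold lower number (0.10 log units; that floor lies within the scatter) from compound 1 to compound 4; the limit leaves it open whether they differ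

Compound 1 stands at > 100000 nM, a limit of the assay and not a number, so neither change is shown to carry from one core to the other by the same amount, nor shown to differ.

The compounds shown leave open whether a longer chain in place of the methylsulfanyl or selenium-carrying group, or an amine or carboxylic acid in place of methoxy, would move the number beyond the scatter in this assay.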